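The compounds below may be only part of what the source reports. "The series", "measured", "known", "first", "only" and "open" are said of these compounds alone.

Compound 1 `Cc1cc(O)c(C2=NN(c3ccc(S(N)(=O)=O)cc3)C(c3ccccc3O)C2)cc1Cl` gives 3190 nM in a functional assay on LOX IMVI cells (Homo sapiens) for antiproliferative activity, with a stated time of 48 h; a lower number here means a stronger inhibitor of growth, a higher number a weaker inhibitor of growth.
Compound 2 `Cc1cc(O)c(C2=NN(c3ccc(S(N)(=O)=O)cc3)C(c3ccccc3Cl)C2)cc1Cl` gives 3210 nM.
Compound 3 `Cc1cc(O)c(C2=NN(c3ccc(S(N)(=O)=O)cc3)C(/C=C/c3ccccc3)C2)cc1Cl` gives 16200 nM.

Compound 3 has the highest number of the three and is the weakest growth inhibitor measured here; both other compounds lie well below it, as the steps of a 5.1-fold higher number from compound 1 to compound 3 (0.71 log units; beyond the scatter) and a 5.0-fold higher number from compound 2 to compound 3 (0.70 log units; beyond the scatter) show. Compound 4 `COc1ccc(C2CC(c3cc(Cl)c(C)cc3O)=NN2c2ccc(S(N)(=O)=O)cc2)cc1OC` differs from compound 3 in one place: 3,4-dimethoxyphenyl in place of 2-phenylethenyl on a saturated ring carbon. The two steps that bear on this change ran the other way, from 2-hydroxyphenyl or 2-chlorophenyl to 2-phenylethenyl on that saturated ring carbon, and each raised the number by a modest amount beyond the scatter. Replacing the 2-phenylethenyl group with a ring-bearing group is therefore expected to lower the number in this assay by a modest amount, a 3.6-fold lower number from compound 3 to compound 4 (0.56 log units; beyond the scatter). Compound 4 is estimated at 4500 nM, within 1500 nM to 13000 nM.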

Compound 4, concentration for total growth inhibition: 11000 nM
Estimate against measurement, compound 4: 2.4-fold (0.39 log units) below, within the range that was stated.
By their numbers in this assay, from the lowest: compounds 1 and 2 (each within the scatter of the next); then compounds 4 and 3 (each within the scatter of the next).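

A ring at this saturated ring carbon does not by itself keep the number low in this assay: with 3,4-dimethoxyphenyl there is a 1.5-fold lower number from compound 3 to compound 4 (0.17 log units; within the scatter), so this group cannot be told apart from 2-phenylethenyl. The same group does separate from 2-chlorophenyl and 2-hydroxyphenyl, with a 3.4-fold higher number from compound 2 to compound 4 (0.53 log units; beyond the scatter) and a 3.4-fold higher number from compound 1 to compound 4 (0.54 log units; beyond the scatter). No measurement here explains this difference. On these data alone, it remains open whether a single methoxy on the phenyl ring would behave like 3,4-dimethoxyphenyl. Also open, as far as these compounds go, is how an amine or a carboxylic acid at this carbon would compare.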